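Fluoro substitution on two related anilide cores

The source may report more compounds than this note shows. Statements on the series, on what has been measured and on what is new or still open speak of the compounds shown alone.

Compound 1 `O=C(Nc1ccc(Oc2ccnc3[nH]ccc23)cc1)c1cc2cccnc2n(-c2ccccc2)c1=O` is the reference point of this small set. In a functional assay on NCI-H460 cells (Homo sapiens) for antiproliferative activity, read by MTT assay, with a stated time of 72 h (a lower number here means a stronger inhibitor, a higher number a weaker inhibitor), compound 1 gives 380 nM. Compound 2 `O=C(Nc1ccc(Oc2ccnc3[nH]ccc23)cc1)c1cc2cccnc2n(-c2ccc(F)cc2)c1=O` carries the change (fluoro in place of hydrogen on an aromatic carbon); in this assay compound 2 gives 190 nM, and the step is a 2.0-fold lower number from compound 1 to compound 2 (0.30 log units; within the scatter). Compound 3 `Cn1ccc2c(Oc3ccc(NC(=O)c4cc5cccnc5n(-c5ccccc5)c4=O)cc3)ccnc21` differs from compound 1 by methyl in place of hydrogen on an aromatic nitrogen; in this assay compound 3 gives 560 nM, and the step is a 1.5-fold higher number from compound 1 to compound 3 (0.17 log units; within the scatter). For the measured compounds named here, no step is computed between compound 2 and compound 3; their two values lie beyond the scatter of each other.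

Compound 4 `Cn1ccc2c(Oc3ccc(NC(=O)c4cc5cccnc5n(-c5ccccc5)c4=O)cc3F)ccnc21` has not yet been measured. It differs from compound 3 by fluoro in place of hydrogen on an aromatic carbon. Going by the values given here, this is the same kind of change as the one from compound 1 to compound 2, but not the same change: in compound 2 the fluoro sits para to a large group, whereas in compound 4 it sits ortho to a large group and meta to a large group. Among the compounds with values here, the only precedent within the set is a 2.0-fold lower number from compound 1 to compound 2 (0.30 log units; within the scatter), which lies within the scatter, so the expected step from compound 3 to compound 4 is a 1.6-fold lower number from compound 3 to compound 4 (0.20 log units; within the scatter), a modest shift at most, because the sole comparable step a 2.0-fold lower number from compound 1 to compound 2 (0.30 log units; within the scatter) was itself small. Compound 4 is thus expected to give about 350 nM in this assay, with a plausible range from 150 nM to 900 nM.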

Compound 4, half-maximal inhibitory concentration: 550 nM
Estimate against measurement, compound 4: 1.6-fold (0.20 log units) below; the range from low to high includes it.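

In this assay the fluoro step on the core of compound 3 is a 1.0-fold lower number from compound 3 to compound 4 (0.01 log units; within the scatter), so compound 3 and compound 4 cannot be told apart in this read-out. Set beside the earlier step on the core of compound 1, the new step gives no sign that the outcome of this change depends on the core: the same change on two cores in this assay, a 2.0-fold lower number (0.30 log units; within the scatter) from compound 1 to compound 2 and a 1.0-fold lower number (0.01 log units; within the scatter) from compound 3 to compound 4, 2.0-fold (0.29 log units) apart, within the scatter of two such steps. This does not show that the change carries over unaltered: both steps are small, the two cores differ by the methyl on the aromatic nitrogen, and the fluoro is para to a large group in compound 2 but ortho to a large group and meta to a large group in compound 4.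

Still open, going by these compounds, is whether fluoro in one and the same place would give matching steps on both cores, and so whether place or core matters at all for this change. Also open, on these data alone, is whether a different group on these aromatic carbons, such as chloro, methoxy, an amine or a carboxylic acid, would give a step beyond the scatter on either core.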